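Swapping chloro for methoxy on a weak sulfonamide

This account rests on a few compounds, and the source may have more. Where it says the series, first, only, none or still open, it means among the compounds named here.

Measured so far:
compound 1, `CC1CCN(C2CCN(S(=O)(=O)c3cccc(N)c3)CC2)CC1`, 3400 nM
compound 2, `COc1ccc(-c2cccc(S(=O)(=O)N3CCC(N4CCC(C)CC4)CC3)c2)cc1`, 23 nM
compound 3, `CC1CCN(C2CCN(S(=O)(=O)c3cccc(Cl)c3)CC2)CC1`, only a limit

In a functional assay on DLD-1 cells (Homo sapiens) for antiproliferative activity, read by CellTiter-Glo, with a stated time of 72 h (a lower number here means a stronger inhibitor, a higher number a weaker inhibitor), compound 3 gives > 5000 nM, which is a limit of the assay rather than a number, because it sits at the limit of > 5000 nM in this assay, at which 1 of the 3 values shown sits. Compound 3 therefore stands at the weak end of the three measured compounds, with no exact value. The new compound 4 has the structure `COc1cccc(S(=O)(=O)N2CCC(N3CCC(C)CC3)CC2)c1` and differs from compound 3 by methoxy in place of chloro on an aromatic carbon.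

Going by the values given here, three measured steps bear on this change. The step of an at least 1.4-fold higher number from compound 1 to compound 3 (0.16 log units; that floor lies within the scatter) shows that exchanging one small group for another at this position moves the number little. The steps of a 150-fold lower number from compound 1 to compound 2 (2.17 log units; beyond the scatter) and an at least 210-fold higher number from compound 2 to compound 3 (2.33 log units; beyond the scatter) were both large, but each involved the much bigger 4-methoxyphenyl group, which compound 4 does not carry. Methoxy is a small group like amino or chloro, so no step beyond the scatter is expected here. Compound 4 is therefore expected to sit near compound 3, an estimated at least 1.4-fold lower number from compound 3 to compound 4 (0.15 log units; that floor lies within the scatter), giving an expected value of 3500 nM in this assay with a range from 1200 nM to 12000 nM.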

Compound 4, half-maximal inhibitory concentration: > 5000 nM
Compound 4 ended at the assay's limit; the forecaster's own chance of this, stated with the estimate: 45%; middle value at least 1.4-fold (0.15 log units) away from the limit.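

Compound 4, like compound 3, carries a value that is a limit of the assay and not a number, so the step between them cannot be read because both values sit at that limit: the limit of > 5000 nM in this assay, at which 2 of the 4 values shown sit.

Cutting 4-methoxyphenyl back to methoxy gives an at least 210-fold higher number from compound 2 to compound 4 (2.33 log units; beyond the scatter), which shows that the methoxy group alone does not reproduce the strength of compound 2. Against amino, methoxy gives an at least 1.4-fold higher number from compound 1 to compound 4 (0.16 log units; that floor lies within the scatter), so this pair shows no clear difference, and three small groups at this position now all leave the compounds weak.

On these data alone, it remains open whether the strength of compound 2 needs the added aromatic ring alone or that ring together with its methoxy group. A plain phenyl, a pyridyl ring or a butyl chain at this position would help separate these possibilities.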